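One Added Carbonyl on a Compound at the Assay Limit

The compounds below may be only part of what the source reports. "The series", "measured", "known", "first", "only" and "open" are said of these compounds alone.

Of the compounds shown here, three have been tested so far: compound 1 (`O=C(NNc1ccccc1F)c1ccc(NS(=O)(=O)c2cnc(O)nc2O)cc1`), compound 2 (`O=C(NNc1ccccc1F)c1ccccc1NS(=O)(=O)c1cnc(O)nc1O`) and compound 3 (`O=C(NNC(=O)c1cccc(Cl)c1)c1ccc(NS(=O)(=O)c2cnc(O)nc2O)cc1`). In a functional assay on SGC-7901 cells (Homo sapiens) for antiproliferative activity, read by MTT assay, with a stated time of 24 h (a lower number here means a stronger inhibitor, a higher number a weaker inhibitor), compound 1 gives 16000 nM and compound 3 gives 8610 nM as measured numbers. Compound 2 gives > 20000 nM in the same test, and that is a limit of the assay and not a number.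

Compound 4 (`O=C(NNC(=O)c1ccccc1NS(=O)(=O)c1cnc(O)nc1O)c1ccccc1F`) has not yet been measured. It departs from compound 2 by a single change ((2-fluorophenyl)carbonyl in place of 2-fluorophenyl on an amine nitrogen), namely (2-fluorophenyl)carbonyl in place of 2-fluorophenyl on an amine nitrogen.

Among the measured compounds shown here, one measured step bears on this, a close relative with a different group entering: (3-chlorophenyl)carbonyl in place of 2-fluorophenyl on an amine nitrogen. Going by that single example (a 1.9-fold lower number from compound 1 to compound 3 (0.27 log units; within the scatter)), no change beyond the scatter is expected in this assay for compound 4. The starting point offers only a limit, so compound 4 may well return a limit too. The expected move is an at least 1.1-fold lower number from compound 2 to compound 4 (0.04 log units; that floor lies within the scatter) by this estimate, and it is a loose one. Compound 4 is estimated at 18000 nM with a range from 9000 nM to 36000 nM as the expected span.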

Compound 4, half-maximal inhibitory concentration: > 20000 nM
Compound 4 ended at the assay's limit (the forecaster's own chance of this, stated with the estimate: 50%); middle value at least 1.1-fold (0.04 log units) away from the limit.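

In this assay compound 4 gives > 20000 nM, which is a limit of the assay and not a number. Compound 2 also stands at a limit, so no step between compound 2 and compound 4 can be read: the limit of > 20000 nM in this assay, at which 2 of the 4 values shown sit.

The compounds shown leave open whether (2-fluorophenyl)carbonyl in place of 2-fluorophenyl changes activity at all in this assay.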